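The source may report more compounds than this note shows. Statements on the series, on what has been measured and on what is new or still open speak of the compounds shown alone.

Measured compounds: compound 1 `CNC(=N)Nc1nc(-c2ccc(OC)cc2)c(-c2ccc(OC)cc2)s1`, 62 nM; compound 2 `COc1ccc(-c2nc(/N=C(\N)N3CCOCC3)sc2-c2ccc(OC)cc2)cc1`, < 1000 nM (a limit); compound 3 `COc1ccc(-c2nc(CNC(C)=O)sc2-c2ccc(OC)cc2)cc1`, 15 nM.

In a functional assay with Oryctolagus cuniculus as the target (a lower number here means a stronger inhibitor, a higher number a weaker inhibitor), compound 1 gives 62 nM. Compound 3 gives 15 nM in this assay. For compound 2 this assay reports only a limit, < 1000 nM, so compound 2 stands at the limit of < 1000 nM in this assay, at which 1 of the 3 values shown sits, and has no number. Among the compounds with values here, the steps a step that the limit leaves unreadable from compound 1 to compound 2 and a step that the limit leaves unreadable from compound 2 to compound 3 are unreadable for that reason; the one readable step is a 4.1-fold lower number from compound 1 to compound 3 (0.62 log units; beyond the scatter), which does not touch compound 2.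

Compound 4 `CCOC(=O)/C=C/c1nc(-c2ccc(OC)cc2)c(-c2ccc(OC)cc2)s1` carries a group of 7 heavy atoms (5 carbon, 2 oxygen; no ring) in place of a group of 9 heavy atoms (5 carbon, 3 nitrogen, 1 oxygen; one six-membered non-aromatic ring with 2 hetero atoms), on an aromatic carbon. Within the data shown here, no measured step covers this change; the readable step of a 4.1-fold lower number from compound 1 to compound 3 (0.62 log units; beyond the scatter) shows only that exchanging the group on that aromatic carbon moved the number modestly. For compound 4 the expected step is a step that the limit leaves unreadable from compound 2 to compound 4, a rough placing rather than a reading. Compound 4 is estimated at 250 nM, range 30 nM to 2000 nM.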

Compound 4, half-maximal inhibitory concentration: 20 nM
Beside the measured number, compound 4's estimate is 13-fold (1.10 log units) above it, and the stated range ends above it.
By their numbers in this assay, from the lowest: compounds 3 and 4 (each within the scatter of the next); then compound 1.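

In this assay the aromatic carbon next to the ring nitrogen and next to the ring sulfur takes 2-(ethoxycarbonyl)ethenyl as readily as acetamidomethyl, with a 1.3-fold higher number from compound 3 to compound 4 (0.12 log units; within the scatter). The new group also reads clear of the group in compound 1, with a 3.1-fold lower number from compound 1 to compound 4 (0.49 log units; beyond the scatter), so two unlike groups now sit on the same side of compound 1. Compound 2 carries only a limit, and the steps to and from it cannot be read because of that limit: the limit of < 1000 nM in this assay, at which 1 of the 4 values shown sits.

As far as these compounds go, how a carboxylic acid or a simple amine on this carbon would read stays open. So does the effect of a longer chain in place of the ethenyl link.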